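From trifluoromethyl to bromo at the assay limit

The compounds below may be only part of what the source reports. "The series", "measured", "known", "first", "only" and "open" are said of these compounds alone.

Of the compounds shown here, three sharing one core have been tested in a functional assay on HUVEC cells (Homo sapiens) for antiproliferative activity, read by MTT assay, with a stated time of 24 h (on this read-out higher numbers stand for weaker inhibition and lower numbers for stronger inhibition), and none has yielded an actual number. Compound 1 (`C=CCOc1ccc2c(=O)c(-c3cc(OC)c(OC)cc3OC)coc2c1`) reads > 10000 nM there, which is a limit of the assay. Compound 2 (`C#CCOc1ccc2c(=O)c(-c3cc(OC)c(OC)cc3OC)coc2c1`) reads > 10000 nM there, again a limit. On these data alone, compound 3 (`COc1cc(OC)c(-c2coc3cc(OCc4ccccc4C(F)(F)F)ccc3c2=O)cc1OC`) reads > 10000 nM there, also a limit, so its true position is unknown. All three therefore stand at the same mark, the limit of > 10000 nM in this assay, at which 3 of the 3 values shown sit, and nothing separates them.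

Compound 4 (`COc1cc(OC)c(-c2coc3cc(OCc4ccccc4Br)ccc3c2=O)cc1OC`) is compound 3 with bromo in place of trifluoromethyl on an aromatic carbon, so that 2-(trifluoromethyl)benzyl becomes 2-bromobenzyl. Going by the values given here, two measured steps bear on this swap, namely a step that the two limits leave unreadable from compound 1 to compound 3 together with a step that the two limits leave unreadable from compound 2 to compound 3 and neither offers a size to carry over. Both changed the group on the same chain carbon, yet neither produced a number. The expected move is therefore only a rough estimate, a step that the limit leaves unreadable from compound 3 to compound 4 in this assay with no firm direction. Compound 4 is estimated at 15000 nM with an expected range from 5000 nM to 50000 nM and it may well return only a limit again.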

Compound 4, half-maximal inhibitory concentration: > 10000 nM
Compound 4 gave a limit, no number; the forecaster's own chance of this, stated with the estimate: 85%; the middle value does not contradict the limit.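

In this assay compound 4 gives > 10000 nM, which is a limit and not a number. Going by these compounds alone, no new step from compound 1, compound 2 or compound 3 to compound 4 can be read, and all four compounds stand at one mark: the limit of > 10000 nM in this assay, at which 4 of the 4 values shown sit. The compounds shown leave open whether these groups differ in antiproliferative activity at all, since each true value remains unknown.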